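The source may report more compounds than this note shows. Statements on the series, on what has been measured and on what is new or still open speak of the compounds shown alone.

Measured so far:
compound 1, `S=C(Nc1ccccc1)N1N=C(c2ccccc2)CC1c1ccc2c(c1)OCCO2`: in a functional assay on HCT-116 cells (Homo sapiens) for antiproliferative activity, read by MTT assay, with a stated time of 48 h (a lower number here means a stronger inhibitor of growth, a higher number a weaker inhibitor of growth), compound 1 gives 57600 nM.
compound 2, `S=C(Nc1ccccc1)N1N=C(c2ccc(Cl)cc2)CC1c1ccc2c(c1)OCCO2`: in this assay compound 2 reaches only the assay limit > 200000 nM.
compound 3, `O=[N+]([O-])c1ccc(C2=NN(C(=S)Nc3ccccc3)C(c3ccc4c(c3)OCCO4)C2)cc1`: in this assay compound 3 reaches only the assay limit > 200000 nM.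

Compound 3 thus stands at the weak end of the series, where only a limit is known; (the limit of > 200000 nM in this assay, at which 2 of the 3 values shown sit). Compound 4, `S=C(Nc1ccccc1)N1N=C(c2cccc(Cl)c2)CC1c1ccc2c(c1)OCCO2`, differs from it by 3-chlorophenyl in place of 4-nitrophenyl on a carbon with a double bond to nitrogen. Going by the values given here, no measured step shows this exact exchange; the bearing steps are an at least 3.4-fold higher number from compound 1 to compound 3 (0.54 log units; beyond the scatter) and an at least 3.4-fold higher number from compound 1 to compound 2 (0.54 log units; beyond the scatter), both running from the unsubstituted phenyl toward the limit, while a step that the two limits leave unreadable from compound 2 to compound 3. A chloro group on the phenyl ring, as in compound 2, gave a number at the limit, so compound 4 is expected to stay near that limit, with an at least 1.3-fold lower number from compound 3 to compound 4 (0.12 log units; that floor lies within the scatter) as the estimated step. The estimate for compound 4 is 150000 nM, within 40000 nM to 400000 nM.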

Compound 4, concentration for 50% growth inhibition: 138000 nM
For compound 4 the middle estimate is 1.1-fold (0.04 log units) above the measured one; measured number inside the range.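

In this assay, 3-chlorophenyl on the carbon with a double bond to nitrogen gives a readable number where 4-chlorophenyl and 4-nitrophenyl gave only limits, with an at least 1.4-fold lower number from compound 2 to compound 4 (0.16 log units; that floor lies within the scatter) and an at least 1.4-fold lower number from compound 3 to compound 4 (0.16 log units; that floor lies within the scatter). Chloro on the phenyl ring still leaves a weaker inhibitor of growth than the unsubstituted phenyl, with a 2.4-fold higher number from compound 1 to compound 4 (0.38 log units; beyond the scatter). The true size of the first two steps stays unknown: the limit of > 200000 nM in this assay, at which 2 of the 4 values shown sit.

On these data alone, how an amine or a methoxy group on this phenyl ring would read stays open. So does whether any group at this place can give a lower number than compound 1.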